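This account rests on a few compounds, and the source may have more. Where it says the series, first, only, none or still open, it means among the compounds named here.

Compound 1 `CCOc1ccc2ccc(=O)oc2c1CCC(C)C` sets the reference point in this series. In a functional assay on V79 cells (Cricetulus griseus) for cytotoxicity (on this read-out lower numbers stand for stronger inhibition and higher numbers for weaker inhibition), compound 1 gives 5800 nM. Compound 2 `CCCCOc1ccc2ccc(=O)oc2c1CCC(C)C` carries one change relative to compound 1, (ethyl in place of hydrogen on a saturated chain carbon, two bonds along the chain from an oxygen on an aromatic ring), and in this assay compound 2 gives 16000 nM, which is a 2.8-fold higher number from compound 1 to compound 2 (0.44 log units; beyond the scatter). Compound 3 `CC(=O)c1ccc2ccc(=O)oc2c1CCC(C)C` differs from compound 1 in its core by acetyl in place of ethoxy on an aromatic carbon; in this assay compound 3 gives 60000 nM, the weakest of the three measured compounds, reached by a 10-fold higher number from compound 1 to compound 3 (1.01 log units; beyond the scatter) and by a 3.8-fold higher number from compound 2 to compound 3 (0.57 log units; beyond the scatter).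

Compound 4 `CCCC(=O)c1ccc2ccc(=O)oc2c1CCC(C)C` has not been measured. It differs from compound 3 by ethyl in place of hydrogen on a saturated chain carbon bound to a carbonyl carbon. This is the same kind of change as the one from compound 1 to compound 2, occurring twice in all among these compounds, but the surroundings are not identical: in compound 1 the hydrogen sits on a saturated chain carbon two bonds along the chain from an oxygen on an aromatic ring, whereas in compound 3 it sits on a saturated chain carbon bound to a carbonyl carbon, and the two cores themselves differ by acetyl in place of ethoxy on an aromatic carbon.

Among the compounds with values here, with only one measured instance of the change, the expectation for compound 4 rests on that single step. Compound 4 is expected to show a step of a 2.5-fold higher number from compound 3 to compound 4 (0.40 log units; beyond the scatter), because a 2.8-fold higher number from compound 1 to compound 2 (0.44 log units; beyond the scatter) went in the weakening direction by a modest amount. Compound 4 is therefore estimated at 150000 nM, with a plausible range from 60000 nM to 400000 nM.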

Compound 4, half-maximal inhibitory concentration: 58000 nM
Estimate against measurement, compound 4: 2.6-fold (0.41 log units) above; measured number outside the range, below it.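

In this assay, ethyl in place of hydrogen on a saturated chain carbon bound to a carbonyl carbon gives a 1.0-fold lower number from compound 3 to compound 4 (0.01 log units; within the scatter), so the step from acetyl to propylcarbonyl leaves no readable change, and it does not match the earlier step on the core of compound 1: the same change on two cores in this assay, a 2.8-fold higher number (0.44 log units; beyond the scatter) from compound 1 to compound 2 and a 1.0-fold lower number (0.01 log units; within the scatter) from compound 3 to compound 4, 2.9-fold (0.46 log units) apart, beyond the scatter of two such steps. In this series, then, the size of this change does not carry over from the core of compound 1 to the core of compound 3, while the propylcarbonyl compound remains separated from the two alkoxy compounds by a 3.6-fold higher number from compound 2 to compound 4 (0.56 log units; beyond the scatter) and by a 10-fold higher number from compound 1 to compound 4 (1.00 log units; beyond the scatter), much as the acetyl compound is. With a single pair on each core, these compounds do not show why the two steps part, nor how general either step is beyond these four compounds.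

Going by these compounds, it remains open whether a longer chain than propylcarbonyl on the carbonyl carbon would also leave the number unchanged, or whether the absence of a readable step holds only for this one pair. On these data alone, it is equally open what an amine or a carboxylic acid in place of the acetyl would do in this assay.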